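Swapping a Hydroxy for a Methoxy in Compound 3

The compounds below may be only part of what the source reports. "The series", "measured", "known", "first", "only" and "open" are said of these compounds alone.

Of the compounds shown here, two have been tested so far. Compound 1 `Cc1nc2ccc(Br)cc2c(=O)n1NCc1nnc(N2C(=O)CSC2c2ccc(O)cc2)s1` carries a bromo on an aromatic ring, and in a functional assay on the whole organism (strain albino) with Rattus norvegicus as the target, in the maximal electroshock model, with a stated time of 1 h, at a dose of 30 mg/kg by the intraperitoneal route (on this read-out lower numbers stand for less inhibition and higher numbers for more inhibition at the one dose given (going by the name of the read-out)), compound 1 gives 60%. Compound 2 `Cc1nc2ccccc2c(=O)n1NCc1nnc(N2C(=O)CSC2c2ccc(O)cc2)s1` has hydrogen in place of that bromo, and in this assay compound 2 gives 60%. That single change produced no change at the digits printed from compound 1 to compound 2 (within the scatter), so compound 2 stands level with compound 1 on the numbers available.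

Compound 3 `COc1ccc(C2SCC(=O)N2c2nnc(CNn3c(C)nc4ccccc4c3=O)s2)cc1` differs from compound 2 by one change: methyl in place of hydrogen on an oxygen on an aromatic ring. Among the compounds with values here, no measured step involves a change of this kind; the only step known, from compound 1 to compound 2, showed no movement. With both measured values level and nothing pointing in either direction, compound 3 is expected to stay near the same level, a step of no change at the digits printed from compound 2 to compound 3 (within the scatter). The estimate for compound 3 is 60%, with a range from 40% to 80%.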

Compound 3, a percentage reported as inhibition, in the whole organism at one dose (the size of the read-out at that dose, not a potency): 60%
Beside the measured number, compound 3's estimate shows no gap at the digits printed, and the stated range covers the measured number.
By their numbers in this assay, from the lowest: compounds 1, 2 and 3 (each within the scatter of the next).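

In this assay, going from the 4-hydroxyphenyl to the 4-methoxyphenyl group brings no change at the digits printed from compound 2 to compound 3 (within the scatter). The earlier step touched only a bromo on an aromatic carbon, whereas this one tests the oxygen on the aromatic ring and shows that, at this single dose, a methyl can take the place of the hydrogen there without the read-out leaving the scatter, so a free hydroxy is not required to keep this level. Nothing available explains why the read-out holds level.

Going by these compounds, it remains open whether an ethyl or a benzyl on that oxygen, or an amine in place of the hydroxy, would hold the same level. A single dose also cannot tell whether these compounds would stay level at other doses.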